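The source may hold more compounds than are shown below. What is called first, only, known or untested is meant among the compounds shown, and "the series" means these compounds.

Compound 1 `O=S(=O)(c1ccc(F)cc1)N1CCCC(Cn2ccnc2)C1` in an assay on isolated protein for inhibition of Aromatase (Homo sapiens), read by fluorescence (a higher number here means a weaker inhibitor, a lower number a stronger inhibitor), gives 51 nM. Compound 2 `Cc1cc(F)ccc1S(=O)(=O)N1CCCC(Cn2ccnc2)C1` in this assay gives 48 nM; the step of a 1.1-fold lower number from compound 1 to compound 2 (0.03 log units; within the scatter) lies within the scatter, so the two numbers cannot be told apart. Compound 3 `O=S(=O)(c1ccc(OC2CCCC2)cc1)N1CCCC(Cn2ccnc2)C1` is not yet measured; it differs from compound 1 by cyclopentyloxy in place of fluoro on an aromatic carbon. Going by the values given here, no measured step concerns an exchange of the fluoro for a larger oxygen-linked group; the one measured step, a 1.1-fold lower number from compound 1 to compound 2 (0.03 log units; within the scatter), alters a different group and stays within the scatter. The expectation for compound 3 therefore rests on little, and a step of a 1.2-fold higher number from compound 1 to compound 3 (0.07 log units; within the scatter) is estimated, with wide uncertainty. Compound 3 is estimated at 60 nM, range 15 nM to 250 nM.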

Compound 3, half-maximal inhibitory concentration: 14 nM
The estimate for compound 3 lay 4.3-fold (0.63 log units) above the measured number; the whole stated range lies above it.
By their numbers in this assay, from the lowest: compound 3; then compounds 2 and 1 (each within the scatter of the next).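

Going by these compounds alone, the aromatic carbon para to a large group accepts far more than a single fluoro: in this assay cyclopentyloxy in place of fluoro gives a 3.6-fold lower number from compound 1 to compound 3 (0.56 log units; beyond the scatter) and is the first step beyond the scatter. The larger group brings in a five-membered ring of carbon only and a hydrogen-bond acceptor, so the number can move at this position. No available measurement explains the step. As far as these compounds go, whether the oxygen link or the ring carries it stays open. A plain methoxy group, a phenoxy group or an amine at this position would help to separate the two.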